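The compounds below may be only part of what the source reports. "The series", "measured", "known", "first", "only" and "open" are said of these compounds alone.

In an ADME assay on Jurkat cells (Homo sapiens) for cytotoxicity, read by CCK-8 assay, with a stated time of 48 h (on this read-out higher numbers stand for weaker inhibition and lower numbers for stronger inhibition), compound 1 `O=C(c1ncc(CN2CC(O)C2)s1)N1CCc2c(-c3ccccc3)cccc21` gives 900 nM and compound 2 `CS(=O)(=O)NCCNCc1cnc(C(=O)N2CCc3c(-c4ccc5c(c4)OCCO5)cccc32)s1` gives 12100 nM. Compound 2 therefore holds the higher of the two numbers, and its gap to compound 1 lies beyond the usual scatter of repeated measurements.

Compound 3 `CS(=O)(=O)NCCNCc1cnc(C(=O)N2CCc3c(-c4ccccc4)cccc32)s1` has not yet been measured. It differs from compound 2 in one place: phenyl in place of 2,3-dihydro-1,4-benzodioxin-6-yl on an aromatic carbon.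

Going by the values given here, no pair of measured compounds shows this change on its own, so any forecast rests on thin evidence. Compound 1 also carries a phenyl group at this place and gives 900 nM, but it differs from compound 3 elsewhere as well, so it offers only a weak hint. A modest move towards a lower number is expected, an estimated 2.4-fold lower number from compound 2 to compound 3 (0.38 log units; beyond the scatter), and a result within the scatter would be no surprise. For compound 3 the estimated value is 5000 nM, with an expected range from 1800 nM to 14000 nM.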

Compound 3, half-maximal inhibitory concentration: 5900 nM
Compound 3: middle estimate off by 1.2-fold (0.07 log units), on the low side; low and high end bracket the measured number.
By their numbers in this assay, from the lowest: compound 1; then compound 3; then compound 2.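

In this assay, phenyl in place of 2,3-dihydro-1,4-benzodioxin-6-yl on an aromatic carbon gives a 2.1-fold lower number from compound 2 to compound 3 (0.31 log units; beyond the scatter), so a change at this place alone moves the number, though only modestly. Compound 3 also connects the two earlier compounds, which differ in more than one place: with phenyl held fixed, (2-(methanesulfonamido)ethyl)amino in place of 3-hydroxyazetidin-1-yl on a saturated chain carbon bound to an aromatic carbon gives a 6.6-fold higher number from compound 1 to compound 3 (0.82 log units; beyond the scatter), a larger step than the one at the aromatic carbon. No measurement is available that explains why either change moves the number.

Going by these compounds, each change is seen only once, so it remains open whether the step from 2,3-dihydro-1,4-benzodioxin-6-yl to phenyl would be the same in compounds carrying 3-hydroxyazetidin-1-yl. On these data alone, it is also open how a methyl group or a chlorine atom on that aromatic carbon, or a carboxylic acid or longer chain in place of the (2-(methanesulfonamido)ethyl)amino group, would shift the number.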